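A Trifluoromethyl Swap on the Amide Nitrogen

The source may report more compounds than this note shows. Statements on the series, on what has been measured and on what is new or still open speak of the compounds shown alone.

Compound 1 `O=C(Cn1nc(Cc2ccccc2)c2ccccc2c1=O)Nc1ccccc1` gives 66000 nM
Compound 2 `COc1ccc(NC(=O)Cn2nc(Cc3ccccc3)c3ccccc3c2=O)cc1` gives 69000 nM
Compound 3 `O=C(Cn1nc(Cc2ccccc2)c2ccccc2c1=O)Nc1ccc(F)cc1` gives 27000 nM

All three values come from a functional assay on HepG2 cells (Homo sapiens) for antiproliferative activity, read by sulforhodamine B assay, with a stated time of 72 h (a higher number here means a weaker inhibitor, a lower number a stronger inhibitor), and compound 3 has the lowest number of the set. The next compound to be tested is compound 4 `O=C(Cn1nc(Cc2ccccc2)c2ccccc2c1=O)Nc1cccc(C(F)(F)F)c1` which keeps the shared core and carries 3-(trifluoromethyl)phenyl in place of 4-fluorophenyl on the amide-type nitrogen (3-(trifluoromethyl)phenyl in place of 4-fluorophenyl on an amide-type nitrogen). Three measured steps offer some guidance. Fluoro in place of hydrogen gave a 2.4-fold lower number from compound 1 to compound 3 (0.39 log units; beyond the scatter) and fluoro in place of methoxy gave a 2.6-fold lower number from compound 2 to compound 3 (0.41 log units; beyond the scatter) while methoxy in place of hydrogen gave a 1.0-fold higher number from compound 1 to compound 2 (0.02 log units; within the scatter) as its result. Going by the values given here, no measured compound carries trifluoromethyl, so these steps give only a rough idea of scale. All of them are small, and compound 4 gives up the fluoro group of compound 3, so a slightly higher number is the likelier direction. The expected change is a 1.3-fold higher number from compound 3 to compound 4 (0.11 log units; within the scatter) and no step beyond the scatter is expected. Compound 4 is estimated at 35000 nM with 14000 nM to 80000 nM as the expected range.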

Compound 4, half-maximal inhibitory concentration: 3520 nM
The estimate for compound 4 lay 9.9-fold (1.00 log units) above the measured number; the whole stated range lies above it.
By their numbers in this assay, from the lowest: compound 4; then compound 3; then compounds 1 and 2 (each within the scatter of the next).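

In this assay, the group on the amide-type nitrogen can shift the number much further than the fluoro and methoxy changes suggested: adding trifluoromethyl to the plain phenyl ring gives a 19-fold lower number from compound 1 to compound 4 (1.27 log units; beyond the scatter) and stands as a large step. The same holds against the methoxy compound, with a 20-fold lower number from compound 2 to compound 4 (1.29 log units; beyond the scatter) as the result, and even the best earlier compound is passed, with a 7.7-fold lower number from compound 3 to compound 4 (0.88 log units; beyond the scatter) for 3-(trifluoromethyl)phenyl in place of 4-fluorophenyl. No supporting data are available to explain why this change lowers the number so sharply.

The step from 4-fluorophenyl to 3-(trifluoromethyl)phenyl changes both the group and its numbered place on the ring, so the contribution of each remains unresolved. Going by these compounds, it also remains open how a chloro group, a nitrile or an amine on this phenyl ring would compare with trifluoromethyl.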